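Cyclohexyl in place of hexyl on an aromatic nitrogen

A few compounds are considered here, and "the series" means these few. Any claim that something is new, unique, unknown or untested is made for them only; others in the source may bear on it.

Among the compounds with values here, the series so far holds two measured compounds on a shared core: compound 1 (`N[C@H]1CC[C@H](Nc2nc(Nc3ccc(Cl)cc3)c3ncn(C4CCCCC4)c3n2)CC1`) and compound 2 (`CCCCCCn1cnc2c(Nc3ccc(O)cc3)nc(N[C@H]3CC[C@H](N)CC3)nc21`). In a functional assay on BT-474 cells (Homo sapiens) for inhibition, read by fluorescence, with a stated time of 72 h (a higher number here means a weaker inhibitor of growth, a lower number a stronger inhibitor of growth), compound 1 gives 4100 nM and compound 2 gives 7700 nM. These two values lie within the scatter of each other, so compound 2 stands level with compound 1 on the numbers available.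

The next compound is compound 3 (`N[C@H]1CC[C@H](Nc2nc(Nc3ccc(O)cc3)c3ncn(C4CCCCC4)c3n2)CC1`), which differs from compound 2 in one place, with cyclohexyl in place of hexyl on an aromatic nitrogen. Within the data shown here, no measured pair yet isolates this change, so there is no direct guide to its size. Among the measured compounds shown here, the only indirect guide is compound 1, which also carries cyclohexyl and gives 4100 nM in this assay. On that basis, no step beyond the scatter is expected in this assay, in either direction. The expected step is small, a 1.4-fold lower number from compound 2 to compound 3 (0.15 log units; within the scatter). For compound 3 the estimated value is 5500 nM, with an expected range of 2000 nM to 15000 nM.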

Compound 3, concentration for 50% growth inhibition: 27300 nM
Beside the measured number, compound 3's estimate is 5.0-fold (0.70 log units) below it, and the stated range ends below it.
By their numbers in this assay, from the lowest: compounds 1 and 2 (each within the scatter of the next); then compound 3.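

With the hydroxy held constant, this assay now isolates the change on the aromatic nitrogen: cyclohexyl in place of hexyl gives a 3.5-fold higher number from compound 2 to compound 3 (0.55 log units; beyond the scatter) and so, at this position, the two groups are not interchangeable, even though each has the same count of heavy atoms and the cyclohexyl differs by closing a non-aromatic ring. With cyclohexyl held constant, hydroxy in place of chloro on an aromatic carbon gives a 6.7-fold higher number from compound 1 to compound 3 (0.82 log units; beyond the scatter) and this shows that the group at that second place also moves the number, with compound 3 the weakest of the three inhibitors of growth here. Nothing available bears on the reason for either step.

Going by these compounds, whether the two steps add up or depend on each other stays open, since that question turns on hexyl and chloro together on the shared core. Also open, on these data alone, is how the number responds to a shorter chain such as butyl or a smaller ring such as cyclopentyl on the aromatic nitrogen, or to a methoxy or fluoro group on the aromatic carbon.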